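Nitro in place of methoxy on the sulfonamide aryl ring

The compounds below may be only part of what the source reports. "The series", "measured", "known", "first", "only" and "open" are said of these compounds alone.

Compound 1, `CC1(C)C=C(n2ccccc2=O)c2cc(S(=O)(=O)N=[N+]=[N-])ccc2O1`: 204 nM
Compound 2, `CC1(C)C=C(n2ccccc2=O)c2cc(S(N)(=O)=O)ccc2O1`: 224 nM
Compound 3, `COc1ccc(NS(=O)(=O)c2ccc3c(c2)C(n2ccccc2=O)=CC(C)(C)O3)cc1`: 490 nM

In a functional assay with Rattus norvegicus as the target (on this read-out lower numbers stand for an effect already at smaller amounts and higher numbers for an effect only at larger amounts of compound), compound 3 stands highest of the three measured compounds. The step of a 2.2-fold higher number from compound 2 to compound 3 (0.34 log units; beyond the scatter) is modest but beyond the scatter, and the step of a 2.4-fold higher number from compound 1 to compound 3 (0.38 log units; beyond the scatter) is of similar size. Compound 1 and compound 2 lie within the scatter of each other, as the step of a 1.1-fold higher number from compound 1 to compound 2 (0.04 log units; within the scatter) shows.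

Compound 4, `CC1(C)C=C(n2ccccc2=O)c2cc(S(=O)(=O)Nc3ccc([N+](=O)[O-])cc3)ccc2O1`, keeps the shared core and the sulfonamide of compound 3 and differs from it in one place: nitro in place of methoxy on an aromatic carbon. For the measured compounds named here, none of the measured steps touches this position. The steps that exist change what sits on the sulfonyl sulfur or on the sulfonamide nitrogen, and both show that an aryl group on the nitrogen shifts the number only modestly upward. How a substituent on that aryl ring alters the read-out is not shown by any pair.

Going by the values given here, with no measured step bearing on the change, the step of no change at the digits printed from compound 3 to compound 4 (within the scatter) is expected to stay within the scatter. The estimate for compound 4 in this assay is therefore 490 nM, with a range from 220 nM to 1100 nM.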

Compound 4, half-maximal effective concentration: 10200 nM
Compound 4: middle estimate off by 21-fold (1.32 log units), on the low side, and the stated range ends below it.
By their numbers in this assay, from the lowest: compounds 1 and 2 (each within the scatter of the next); then compound 3; then compound 4.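

In this assay, for the compounds shown here, what sits on the sulfonamide aryl ring matters far more than the earlier compounds suggested: nitro in place of methoxy gives a large step (a 21-fold higher number from compound 3 to compound 4 (1.32 log units; beyond the scatter)), whereas adding the 4-methoxyphenyl group to the sulfonamide nitrogen gave only a modest one (a 2.2-fold higher number from compound 2 to compound 3 (0.34 log units; beyond the scatter)). The aryl group on that nitrogen is therefore not a uniformly modest change, since 4-nitrophenyl in place of hydrogen gives a large step (a 46-fold higher number from compound 2 to compound 4 (1.66 log units; beyond the scatter)), and (4-nitrophenyl)amino in place of azido on the sulfonyl sulfur gives another (a 50-fold higher number from compound 1 to compound 4 (1.70 log units; beyond the scatter)). Going by these compounds alone, nothing available explains why this single exchange on the ring moves the number so far.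

The compounds shown leave open whether the rise belongs to nitro alone or whether another group at this place, such as an amine, a nitrile or a carboxylic acid, would fall nearer compound 3 or nearer compound 4. A plain phenyl on the sulfonamide nitrogen would show how much of the gap between compound 3 and compound 4 goes with losing methoxy and how much with gaining nitro.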